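The source may report more compounds than this note shows. Statements on the series, on what has been measured and on what is new or still open speak of the compounds shown alone.

Measured compounds in an ADME assay on MDCK cells (Canis lupus familiaris) for cytotoxicity, read by MTT assay, with a stated time of 3 days; a higher number here means that more compound is tolerated, a lower number that less compound is tolerated:
compound 1 `CC1(C)C[C@H](O)C[C@](C)(CNc2nc3ccccc3s2)C1`: 36800 nM
compound 2 `CC1(C)C[C@H](O)C[C@](C)(CNc2ccccn2)C1`: a limit, > 100000 nM
compound 3 `CC1(C)C[C@H](O)C[C@](C)(CNc2ccccc2)C1`: 37000 nM

Compound 3 gives 37000 nM in this assay, the highest of the two numbers actually read. Compound 1 gives 36800 nM in this assay, and the two values sit within the scatter of each other, so no order between them is claimed. For compound 2 this assay reports only a limit, > 100000 nM; one of the three values sits at that limit, as noted in the limit of > 100000 nM in this assay, at which 1 of the 3 values shown sits.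

For the measured compounds named here, the single step between measured compounds that differ in one place is an at least 2.7-fold lower number from compound 2 to compound 3 (0.43 log units; beyond the scatter), which swaps the whole aromatic group on the amine nitrogen.

Compound 4 `CC1(C)C[C@H](O)C[C@](C)(CNc2ccccc2Cl)C1` differs from compound 3 by chloro in place of hydrogen on an aromatic carbon. No measured step adds a substituent to the aromatic ring, so the chloro change has no direct precedent among these compounds; the step from compound 2 to compound 3 concerns a different kind of change and does not bear on it. With the phenyl retained, no shift beyond the scatter is expected for compound 4 in this assay, the expected step being a 1.2-fold lower number from compound 3 to compound 4 (0.09 log units; within the scatter). Compound 4 is therefore estimated at 30000 nM, with a range from 12000 nM to 80000 nM.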

Compound 4, half-maximal cytotoxic concentration: 6900 nM
Beside the measured number, compound 4's estimate is 4.3-fold (0.64 log units) above it, and the stated range ends above it.
By their numbers in this assay, from the lowest: compound 4; then compounds 1 and 3 (each within the scatter of the next). At a limit, above all of these: compound 2.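

In this assay the step is a 5.4-fold lower number from compound 3 to compound 4 (0.73 log units; beyond the scatter) and shows that the aromatic ring of compound 3 is not indifferent to substitution: one chloro, a single heavy atom, on an aromatic carbon of a six-membered aromatic ring of carbon only, ortho to a large group, moves the number beyond the scatter towards less compound tolerated. For the compounds shown here, the earlier step exchanged the whole aromatic group on the amine nitrogen, so this is the first reading of a change made on the phenyl itself, with the rest of the structure held constant. The one item of supporting data concerns a limit on another compound and gives no reason for this shift.

As far as these compounds go, whether a methyl or a methoxy at this same place, or a chloro on another carbon of the phenyl, would give a similar step remains open, as does whether the effect belongs to chloro or to any group placed there. Compound 2 carries only a limit of > 100000 nM and so offers no base from which a chloro on its pyridin-2-yl group could be read as a step.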